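Swapping the aminomethylphenyl arm for a cyclic guanidine-bearing group

The source may report more compounds than this note shows. Statements on the series, on what has been measured and on what is new or still open speak of the compounds shown alone.

Three analogues sharing one core have been measured in an assay on isolated protein for binding affinity to Gonadotropin-releasing hormone receptor (Rattus norvegicus); a lower number here means a stronger inhibitor, a higher number a weaker inhibitor. Compound 1 `Cc1cc2c(cc1Cc1ccc(C(=O)NC[C@H]3CC[C@H](C(N)=O)CC3)o1)C(C)(C)CCC2(C)C` gives 270 nM. Compound 2 `Cc1cc2c(cc1Cc1ccc(C(=O)NC[C@H]3CC[C@H](C(=O)O)CC3)o1)C(C)(C)CCC2(C)C` carries an acid where compound 1 carries an amide. Compound 2 gives 3000 nM, and compound 3 `Cc1cc2c(cc1Cc1ccc(C(=O)NCc3ccc(CN)cc3)o1)C(C)(C)CCC2(C)C` gives 280 nM. Among these three, compound 3 stands second highest, close to compound 1, while the gap to compound 2 is clear: the step was an 11-fold lower number from compound 2 to compound 3 (1.03 log units; beyond the scatter).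

Compound 4 `Cc1cc2c(cc1Cc1ccc(C(=O)NCC3CCN(C(=N)N)CC3)o1)C(C)(C)CCC2(C)C` has not yet been measured. It differs from compound 3 in one place: a group of 9 heavy atoms (6 carbon, 3 nitrogen; one six-membered non-aromatic ring with 1 hetero atom) in place of a group of 8 heavy atoms (7 carbon, 1 nitrogen; one six-membered aromatic ring of carbon only), on a saturated chain carbon bound to an amide-type nitrogen.

Two measured steps speak to this change. The step of an 11-fold higher number from compound 1 to compound 2 (1.05 log units; beyond the scatter) shows that the side chain end can move the number a long way, whereas the step of a 1.0-fold higher number from compound 1 to compound 3 (0.02 log units; within the scatter) shows that a 4-carbamoylcyclohexyl and a 4-(aminomethyl)phenyl at this position give the same result. Both of the well-tolerated ends carry hydrogen-bond donors, as does the entering group of compound 4, so a move of the size seen for the acid is not expected. The expected step is a 1.4-fold lower number from compound 3 to compound 4 (0.15 log units; within the scatter). Compound 4 is therefore estimated at 200 nM, with a range from 60 nM to 700 nM.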

Compound 4, inhibition constant: 2040 nM
Compound 4: the middle estimate sits 10-fold (1.01 log units) below what was measured; measured number outside the range, above it.
By their numbers in this assay, from the lowest: compounds 1 and 3 (each within the scatter of the next); then compounds 4 and 2 (each within the scatter of the next).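

Carrying hydrogen-bond donors is not enough at this position on its own: in this assay the guanidine-bearing group gives a 7.3-fold higher number from compound 3 to compound 4 (0.86 log units; beyond the scatter) and, against the carbamoylcyclohexyl arm, a 7.6-fold higher number from compound 1 to compound 4 (0.88 log units; beyond the scatter) in the same direction. It also matches the acid-bearing arm, with a 1.5-fold lower number from compound 2 to compound 4 (0.17 log units; within the scatter) as the step, so among these four compounds the higher numbers at this position are not confined to the carboxylic acid. Nothing measured here explains this drop, and no separate result bears on it.

Compound 4 changes the ring and the group at its end together, so these compounds cannot show which of the two accounts for the higher number. A guanidine carried on the aromatic ring of compound 3, or an aminomethyl group carried on the non-aromatic ring of compound 4, would separate the two changes and show whether the guanidine or the ring matters more.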